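The compounds below may be only part of what the source reports. "The series", "measured", "known", "first", "only" and "open" are said of these compounds alone.

Compound 2, `N=C(N)c1ccc(-c2ccc(-c3ccc(Cl)cc3)s2)s1`, was examined in a functional assay on PC-3 cells (Homo sapiens) for inhibition, read by sulforhodamine B assay, with a stated time of 48 h (on this read-out lower numbers stand for stronger inhibition of growth and higher numbers for weaker inhibition of growth), where compound 2 gives 1860 nM. Compound 1, `N=C(N)c1ccc(-c2ccc(-c3ccc(Cl)cc3)o2)o1`, was measured in the same way, and in this assay compound 1 gives 1810 nM. Going by the values given here, of these two numbers the one for compound 2 is the higher, but the two values lie within the scatter of each other, so nothing can be said about an order between compound 1 and compound 2 on this basis.

The step now goes from compound 2 to compound 3, `N=C(N)c1ccc(-c2ccc(-c3ccc(F)cc3)s2)s1`, which has not yet been measured in this assay. The structural change is fluoro in place of chloro on an aromatic carbon, with no change in ring count, donors, acceptors or charge. Among the compounds with values here, no step between measured compounds of this kind is available to calibrate the exchange. The author expects the step from compound 2 to compound 3 to be a 1.6-fold higher number from compound 2 to compound 3 (0.21 log units; within the scatter), a modest move toward weaker growth inhibition that may not rise clearly above the scatter. Compound 3 is accordingly estimated at 3000 nM, with a range from 1500 nM to 6500 nM.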

Compound 3, concentration for 50% growth inhibition: 1770 nM
Compound 3: the middle estimate sits 1.7-fold (0.23 log units) above what was measured, and the stated range covers the measured number.
By their numbers in this assay, from the lowest: compounds 3, 1 and 2 (each within the scatter of the next).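

In this assay, fluoro in place of chloro on an aromatic carbon of a six-membered aromatic ring of carbon only, para to a large group, gives a 1.1-fold lower number from compound 2 to compound 3 (0.02 log units; within the scatter) and this step lies within the scatter. Going by these compounds alone, it is the first step between measured compounds that touches this position, and it shows that the exchange of these two halogens does not separate compound 2 from compound 3 on this read-out. Nothing available explains this outcome or says whether the two groups act alike in any other respect.

The compounds shown therefore say nothing about how far the position accepts a group other than a halogen, such as a methoxy group, an amine, a carboxylic acid or a longer chain, any of which might or might not move the number beyond the scatter. From the compounds shown here alone, whether the same exchange of chloro for fluoro on the core of compound 1 would give a step of similar size also stays open.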